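Swapping the Tetrazole for an Imidazole on the Sulfur Chain

This account rests on a few compounds, and the source may have more. Where it says the series, first, only, none or still open, it means among the compounds named here.

Going by the values given here, compound 2 `N#Cc1c(N)nc(SCc2nnn[nH]2)c(C#N)c1-c1ccc(OCC2CC2)cc1` has the lowest of the two numbers so far: in an assay on CHO cells for displacement of a labelled ligand from adenosine receptor A1 (Homo sapiens), read by scintillation counting, with a stated time of 90 min, tested at 1 uM (on this read-out lower numbers stand for less inhibition and higher numbers for more inhibition at the one concentration tested (going by the name of the read-out)), compound 2 gives 3%, while compound 1 `N#Cc1c(N)nc(SCC(N)=O)c(C#N)c1-c1ccc(OCC2CC2)cc1` gives 31%. Compound 3 `N#Cc1c(N)nc(SCc2cnc[nH]2)c(C#N)c1-c1ccc(OCC2CC2)cc1` differs from compound 2 by 1H-imidazol-5-yl in place of 1H-tetrazol-5-yl on a saturated chain carbon bound to a sulfur. Among the compounds with values here, no measured pair shows this exact swap; the only known step at this chain carbon, a number 28 percentage points lower from compound 1 to compound 2 (beyond the scatter), shows that a group there can shift the number modestly. Some return toward the number of compound 1 seems plausible. The expected step is a number 12 percentage points higher from compound 2 to compound 3 (beyond the scatter). Compound 3 is therefore estimated at 15%, between 0% and 40%.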

Compound 3, a percentage reported as inhibition, at one concentration (the size of the read-out at that concentration, not a potency): 1%
For compound 3 the middle estimate is 14 percentage points above the measured one, within the range that was stated.
By their numbers in this assay, from the lowest: compounds 3 and 2 (each within the scatter of the next); then compound 1.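

Putting 1H-imidazol-5-yl in place of 1H-tetrazol-5-yl on the saturated chain carbon bound to a sulfur gives a number 2 percentage points lower from compound 2 to compound 3 (within the scatter) in this assay, so this read-out does not separate these two rings. Set against carbamoyl, the same ring gives a number 30 percentage points lower from compound 1 to compound 3 (beyond the scatter), so both five-membered aromatic rings now stand well under compound 1. No measurement here offers a reason for this result.

Still open, as far as these compounds go, is where a carboxylic acid or an amine on this chain carbon would fall relative to compound 1. From the compounds shown here alone, a longer chain carrying the imidazole is equally open.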